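The source may report more compounds than this note shows. Statements on the series, on what has been measured and on what is new or still open speak of the compounds shown alone.

Measured so far:
compound 1 `CCN(CC)CC(=O)Nc1ccc(-c2nc3cc(C(F)(F)F)ccc3n2C)cc1` — 90000 nM
compound 2 `COc1ccc(-c2nc3cc(Cl)c(Cl)cc3[nH]2)cc1` — 30000 nM
compound 3 `O=C(CN1CCCCC1)Nc1ccc(-c2nc3ccccc3[nH]2)cc1` — a limit, > 100000 nM

In an ADME assay on Vero cells (Chlorocebus sabaeus) for cytotoxicity (a lower number here means that less compound is tolerated, a higher number that more compound is tolerated), compound 1 gives 90000 nM, the highest of the two numbers shown. Its nearest neighbour is compound 2, whose value in this assay, 30000 nM, is a lower number by a margin beyond the usual scatter. For compound 3 this assay reports only a limit, > 100000 nM, so no number stands against it; this is the case described by the limit of > 100000 nM in this assay, at which 1 of the 3 values shown sits.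

The compound to be measured next is compound 4 `Cn1c(-c2ccc(NC(=O)CN3CCN(c4ccccc4)CC3)cc2)nc2cc(C(F)(F)F)ccc21`. Compared with compound 1 its change is 4-phenylpiperazin-1-yl in place of diethylamino on a saturated chain carbon bound to a carbonyl carbon. Among the compounds with values here, no step between two measured compounds resembles this exchange, so the expectation rests on compound 1 alone. A larger group enters, and a step toward a lower number, modest in size, is expected rather than none. Compound 4 is therefore estimated at 40000 nM in this assay, with a range from 15000 nM to 100000 nM. The expected step is a 2.3-fold lower number from compound 1 to compound 4 (0.35 log units; beyond the scatter).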

Compound 4, half-maximal cytotoxic concentration: 30000 nM
Estimate against measurement, compound 4: 1.3-fold (0.12 log units) above; the range from low to high includes it.
By their numbers in this assay, from the lowest: compounds 2 and 4 (each within the scatter of the next); then compound 1. At a limit, above all of these: compound 3.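

In this assay, within the data shown here, the exchange on the saturated chain carbon bound to a carbonyl carbon is the first single change that can be read, and it gives a 3.0-fold lower number from compound 1 to compound 4 (0.48 log units; beyond the scatter). The place therefore responds to the amine it carries: 4-phenylpiperazin-1-yl in place of diethylamino moves the number beyond the scatter, though only modestly, and compound 4 still reads 30000 nM. Nothing measured here accounts for this step.

One exchange cannot separate the contribution of the piperazine ring from that of the phenyl ring it carries. As far as these compounds go, it remains open whether a morpholine or an unsubstituted piperazine in this place would read closer to compound 1 or to compound 4.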